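Removing Bromine from a Cytotoxic Indole Series

The source may report more compounds than this note shows. Statements on the series, on what has been measured and on what is new or still open speak of the compounds shown alone.

Compound 1, `COc1cc(/C(Cl)=C/C=C(\C#N)C(=O)c2c[nH]c3ccccc23)cc(OC)c1OC`: in a functional assay on MCF7 cells (Homo sapiens) for cytotoxicity, read by sulforhodamine B assay, with a stated time of 48 h (a higher number here means that more compound is tolerated, a lower number that less compound is tolerated), compound 1 gives > 100000 nM, which is a limit of the assay rather than a number.
Compound 2, `COc1ccc(/C(Cl)=C/C=C(\C#N)C(=O)c2c[nH]c3ccc(Br)cc23)cc1`: compound 2 gives > 100000 nM, also a limit.
Compound 3, `COc1ccc2[nH]cc(C(=O)/C(C#N)=C/C=C(\Cl)c3ccc(Br)cc3)c2c1`: compound 3 gives > 100000 nM, again a limit.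

Compound 2 therefore stands exactly where the other two measured compounds stand, at the limit of > 100000 nM in this assay, at which 3 of the 3 values shown sit. Since its value is a limit, it cannot be ranked against compound 1 or compound 3; all three simply show that the cells tolerated the highest concentration tested.

Compound 4, `COc1ccc(/C(Cl)=C/C=C(\C#N)C(=O)c2c[nH]c3ccccc23)cc1`, differs from compound 2 by one change: hydrogen in place of bromo on an aromatic carbon. Among the compounds with values here, no pair of measured compounds differs in just one place, so no measured step tells how such a change moves the read-out. Because every value shown sits at the limit of > 100000 nM in this assay, at which 3 of the 3 values shown sit, no direction can be read from the data, and the most plausible outcome is a further limit, no step beyond the scatter.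

Compound 4 is expected to give 150000 nM. The expected step is a step that the limit leaves unreadable from compound 2 to compound 4.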

Compound 4, concentration lethal to 50% of the cells: > 100000 nM
Compound 4: no number, only a limit; the forecaster's own chance of this, stated with the estimate: 80%; the middle value does not contradict the limit.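

Within the data shown here, compound 2 and compound 4 both give only a limit rather than a number, so no step between them can be read: the limit of > 100000 nM in this assay, at which 4 of the 4 values shown sit. The compounds shown leave open whether hydrogen in place of bromo on an aromatic carbon changes cytotoxicity at all.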